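A few compounds are considered here, and "the series" means these few. Any claim that something is new, unique, unknown or untested is made for them only; others in the source may bear on it.

Measured so far in a functional assay on SGC-7901 cells (Homo sapiens) for antiproliferative activity, read by MTT assay, with a stated time of 24 h; a higher number here means a weaker inhibitor, a lower number a stronger inhibitor:

compound 1, `Cc1cccc(NNC(=O)c2ccc(NS(=O)(=O)c3cnc(O)nc3O)cc2)c1`: > 20000 nM, a limit of the assay
compound 2, `O=C(NNc1ccccc1Cl)c1ccc(NS(=O)(=O)c2cnc(O)nc2O)cc1`: 3630 nM
compound 3, `Cc1cccc(NNC(=O)c2cccc(NS(=O)(=O)c3cnc(O)nc3O)c2)c1`: > 20000 nM, a limit of the assay

Compound 1 and compound 3 are built from the same atoms joined differently; the difference between their two cores is not broken down here. For compound 1 only a limit is reported in this assay. For compound 3 likewise only a limit is reported. Among the compounds with values here, two of the three values so far rest on (the limit of > 20000 nM in this assay, at which 2 of the 3 values shown sit).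

Compound 2 carries a number. The change from compound 1 to compound 2 is 2-chlorophenyl in place of 3-methylphenyl on an amine nitrogen, and the step it made reads an at least 5.5-fold lower number from compound 1 to compound 2 (0.74 log units; beyond the scatter).

Compound 4, `O=C(NNc1ccccc1Cl)c1cccc(NS(=O)(=O)c2cnc(O)nc2O)c1`, is not yet measured. It differs from compound 3 by 2-chlorophenyl in place of 3-methylphenyl on an amine nitrogen, the same change made on the core of compound 3. The expected step in this assay is an at least 3.3-fold lower number from compound 3 to compound 4 (0.52 log units; beyond the scatter), resting on an at least 5.5-fold lower number from compound 1 to compound 2 (0.74 log units; beyond the scatter) being at least a lower number while compound 3 starts from a limit only. Compound 4 is expected at 6000 nM, between 2000 nM and 30000 nM, with a real chance that only a limit is returned again.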

Compound 4, half-maximal inhibitory concentration: 2270 nM
The estimate for compound 4 lay 2.6-fold (0.42 log units) above the measured number; low and high end bracket the measured number.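

In this assay, 2-chlorophenyl in place of 3-methylphenyl on an amine nitrogen gives an at least 8.8-fold lower number from compound 3 to compound 4 (0.94 log units; beyond the scatter), so a lower number appears on both cores shown: the same change on two cores in this assay, an at least 5.5-fold lower number (0.74 log units; beyond the scatter) from compound 1 to compound 2 and an at least 8.8-fold lower number (0.94 log units; beyond the scatter) from compound 3 to compound 4; the limit leaves it open whether they differ

Compound 3 has only a limit of the assay, > 20000 nM.

The true size of the step on this core therefore stays unknown, and the data show a shared direction but no shared size, so they do not show whether one core responds more than the other: the limit of > 20000 nM in this assay, at which 2 of the 4 values shown sit.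

The step exchanges 3-methylphenyl for 2-chlorophenyl as a whole, and the compounds shown do not separate the swap of methyl for chlorine from the change in where the group sits on the ring. On these data alone, it also remains open whether the lower number extends to other groups on that amine nitrogen, such as a plain phenyl or a fluorophenyl.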